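A few compounds are considered here, and "the series" means these few. Any claim that something is new, unique, unknown or untested is made for them only; others in the source may bear on it.

Working notes on the series.

Compound 2 `CCCCCCC(C#CC(=O)OC)O/C=C/C(=O)OC` is the methyl ester of the series. In a functional assay on HBL-100 cells (Homo sapiens) for antiproliferative activity, read by sulforhodamine B assay, with a stated time of 48 h (on this read-out higher numbers stand for weaker inhibition of growth and lower numbers for stronger inhibition of growth), compound 2 gives 2500 nM, the highest of the two numbers measured; the nearest is compound 3 `CCOC(=O)C#CC(O/C=C/C(=O)OC)C(C)C`, which in this assay gives 880 nM. Compound 1 `CCCCCCC(C#CC(=O)O)O/C=C/C(=O)OC` is the free acid; in this assay compound 1 sits at a limit, > 100000 nM. For the measured compounds named here, the one measured step, an at least 40-fold lower number from compound 1 to compound 2 (1.60 log units; beyond the scatter), rests on (the limit of > 100000 nM in this assay, at which 1 of the 3 values shown sits).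

Compound 4 `COC(=O)C#CC(C)O/C=C/C(=O)OC` is the unmeasured member. Its change from compound 2 is hydrogen in place of pentyl on a saturated chain carbon, two bonds along the chain from an oxygen on an unsaturated carbon and a triple-bonded carbon. Going by the values given here, no measured step touches this position: the step from compound 1 to compound 2 concerns the ester oxygen, not the saturated chain, and compound 3 differs from compound 2 in more than one place, so its number only shows where a branched chain with an ethyl ester falls. The expected step from compound 2 to compound 4 is therefore uncertain and is put at a 2.0-fold higher number from compound 2 to compound 4 (0.30 log units; within the scatter), a modest rise in the number. For compound 4 the estimate in this assay is 5000 nM, with a range from 1500 nM to 20000 nM.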

Compound 4, concentration for 50% growth inhibition: 300 nM
For compound 4 the middle estimate is 17-fold (1.22 log units) above the measured one, and the stated range ends above it.
By their numbers in this assay, from the lowest: compound 4; then compound 3; then compound 2. At a limit, above all of these: compound 1.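

In this assay, the change at this saturated chain carbon now has a measured size: an 8.3-fold lower number from compound 2 to compound 4 (0.92 log units; beyond the scatter). On this methyl ester, hydrogen in place of pentyl therefore gives stronger inhibition of growth, so the pentyl group is not required for the activity seen with compound 2. Nothing shown accounts for the direction or size of this step.

Open, from the compounds shown here alone, is how chains of intermediate length, such as ethyl or propyl, or a chain longer than pentyl would read at this position, and whether an amine or a hydroxyl group there would keep the activity. Also open, going by these compounds, is whether the carboxylic acid matching compound 4 would repeat the large gap seen between the acid and the methyl ester that carry the pentyl group.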